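A few compounds are considered here, and "the series" means these few. Any claim that something is new, unique, unknown or untested is made for them only; others in the source may bear on it.

Measured so far:
compound 1 `CCC1(Cc2ccccc2)OS(=O)(=O)C=C1OCC#N` in an ADME assay on HEL cells (Homo sapiens) for cytotoxicity, with a stated time of 3 days (a higher number here means that more compound is tolerated, a lower number that less compound is tolerated), gives > 200000 nM, which is a limit of the assay.
compound 2 `CCC1(Cc2ccccc2)OS(=O)(=O)C=C1OCc1ccc([N+](=O)[O-])cc1` in this assay gives < 200000 nM, also a limit of the assay.
compound 3 `CCC1(Cc2ccccc2)OS(=O)(=O)C=C1OCc1ccc(Cl)c(Cl)c1` in this assay gives 36700 nM.

Among the compounds with values here, compound 3 therefore stands as the only firm number among the three; the other two values are limits. Compound 4 `CCC1(Cc2ccccc2)OS(=O)(=O)C=C1OCCCc1ccccc1` differs from compound 3 by phenethyl in place of 3,4-dichlorophenyl on a saturated chain carbon bound to an oxygen on an unsaturated carbon. The measured steps that bear on this are few. The step of an at least 5.4-fold lower number from compound 1 to compound 3 (0.73 log units; beyond the scatter) shows that a 3,4-dichlorophenyl in place of cyano lowered the tolerated concentration by a modest margin. The step of a number no higher from compound 1 to compound 2 (the limit leaves the size open) leaves its size open, and the step that the limit leaves unreadable from compound 2 to compound 3 cannot be read at all. Within the data shown here, no measured step exchanges the aryl group directly for a phenethyl chain, so the expectation rests mainly on compound 1 and compound 3. Compound 4 is expected to sit at 90000 nM, between 25000 nM and 200000 nM, an estimated step of a 2.5-fold higher number from compound 3 to compound 4 (0.39 log units; beyond the scatter) toward a higher number.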

Compound 4, half-maximal cytotoxic concentration: 133000 nM
Compound 4: middle estimate off by 1.5-fold (0.17 log units), on the low side; the measured number falls inside the stated range.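

At this saturated chain carbon bound to an oxygen on an unsaturated carbon, phenethyl in place of 3,4-dichlorophenyl gives a 3.6-fold higher number from compound 3 to compound 4 (0.56 log units; beyond the scatter) in this assay, so two groups of equal heavy-atom count, each with one six-membered aromatic ring of carbon only, are told apart here by a step beyond the scatter. Against cyano, the change reads as an at least 1.5-fold lower number from compound 1 to compound 4 (0.17 log units; that floor lies within the scatter), and that floor alone does not separate the two groups. The step from compound 2 to compound 4 cannot be read because compound 2 gives only a limit: the limit of < 200000 nM in this assay, at which 1 of the 4 values shown sits.

What the compounds shown leave open is whether the chlorine atoms or the carbons of the chain account for the step. Going by these compounds, a plain phenyl, or a longer chain ending in an amine, at this place could speak to that, and how either fares in this assay remains unknown.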